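Swapping a methyl for a fluorine on a fatty acid receptor agonist

This account rests on a few compounds, and the source may have more. Where it says the series, first, only, none or still open, it means among the compounds named here.

Two related compounds share the same acid-bearing core and differ only in the aromatic group attached to the thiazole. Compound 1 `Cc1nc(-c2cc3ccccc3o2)sc1COc1ccc2c(c1)OCC2CC(=O)O` carries a benzofuran at that position, but in a functional assay on CHO cells for agonist activity at Free fatty acid receptor 1 (Homo sapiens), read by FLIPR and calcium flux (on this read-out lower numbers stand for an effect already at smaller amounts and higher numbers for an effect only at larger amounts of compound), compound 1 gives "not determined" (no result reported), so no result was reported for compound 1. Within the data shown here, compound 2 `Cc1ccc(-c2nc(C)c(COc3ccc4c(c3)OCC4CC(=O)O)s2)cc1` carries a 4-methylphenyl instead, and in this assay compound 2 gives 73.5 nM, the only number available in this small set.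

Compound 3 `Cc1nc(-c2ccc(F)cc2)sc1COc1ccc2c(c1)OCC2CC(=O)O` is reached from compound 2 by one small change: fluoro in place of methyl on an aromatic carbon. Among the measured compounds shown here, no measured pair shows what this particular exchange does on this core, so the size of its effect is not known from these data. Since the two groups are alike in size and neither adds a donor or an acceptor, the step is expected to be modest, with a slight lean towards needing a little more compound. The step from compound 2 to compound 3 is expected to be a 1.5-fold higher number from compound 2 to compound 3 (0.18 log units; within the scatter). On that basis compound 3 is expected to give about 110 nM in this assay, somewhere between 40 nM and 300 nM.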

Compound 3, half-maximal effective concentration: 48.7 nM
For compound 3 the middle estimate is 2.3-fold (0.35 log units) above the measured one, and the stated range covers the measured number.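

In this assay, fluoro in place of methyl on the aromatic carbon para to a large group gives a 1.5-fold lower number from compound 2 to compound 3 (0.18 log units; within the scatter), so this read-out does not separate the two compounds. Among these compounds, this pair is the first measured comparison at this position on the shared core, and it shows that going from 4-methylphenyl to 4-fluorophenyl leaves the number within the ordinary spread of repeated measurements. Nothing measured here bears on why the two groups give such similar results.

Among the compounds shown here, the pair covers only one exchange, so it remains open how a chlorine, a methoxy group, a trifluoromethyl group or an amine would fare on the same aromatic carbon, and a number for any of them could fall on either side of those seen so far. How a benzofuran at the same place on the thiazole compares with the 4-methylphenyl and 4-fluorophenyl groups also cannot be read from the values shown, which leaves the wider scope of this position unsettled.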